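This account rests on a few compounds, and the source may have more. Where it says the series, first, only, none or still open, it means among the compounds named here.

Compound 3 `C=CC[C@H]1C[C@]2([C@@H](C)Cc3ccc(OC)c(C#N)c3)OCOC2=CC1=O` has the highest number of the three measured compounds in a functional assay on M14 cells (Homo sapiens) for antiproliferative activity, with a stated time of 72 h (a higher number here means a weaker inhibitor, a lower number a stronger inhibitor), giving 180 nM. Compound 1 `C=CC[C@H]1C[C@]2([C@@H](C)Cc3ccc(OC)cc3)OCOC2=CC1=O` gives 20 nM and compound 2 `C=CC[C@H]1C[C@]2([C@@H](C)Cc3ccc(OC)c(C(N)=O)c3)OCOC2=CC1=O` gives 12 nM, so compound 3 lies a 9.0-fold higher number from compound 1 to compound 3 (0.95 log units; beyond the scatter) and a 15-fold higher number from compound 2 to compound 3 (1.18 log units; beyond the scatter).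

Compound 4 `C=CC[C@H]1C[C@]2([C@@H](C)Cc3ccc(OC)c(NC(C)=O)c3)OCOC2=CC1=O` carries the change (acetamido in place of cyano on an aromatic carbon). Going by the values given here, two measured steps bear on this. The step of a 9.0-fold higher number from compound 1 to compound 3 (0.95 log units; beyond the scatter) shows that putting cyano on this carbon raised the number, and the step of a 15-fold higher number from compound 2 to compound 3 (1.18 log units; beyond the scatter) shows that cyano fares much worse than carbamoyl, a group that, like acetamido, brings one hydrogen-bond donor and one acceptor. The step of a 1.7-fold lower number from compound 1 to compound 2 (0.22 log units; within the scatter) shows carbamoyl and hydrogen give numbers close together. Going by these compounds, removing the cyano is therefore expected to bring the number back down, a step of about a 6.0-fold lower number from compound 3 to compound 4 (0.78 log units; beyond the scatter), though acetamido itself is untested here.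

Compound 4 is expected to give about 30 nM in this assay, within a range from 10 nM to 100 nM.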

Compound 4, half-maximal inhibitory concentration: 85 nM
The estimate for compound 4 lay 2.8-fold (0.45 log units) below the measured number; the range from low to high includes it.
By their numbers in this assay, from the lowest: compounds 2 and 1 (each within the scatter of the next); then compound 4; then compound 3.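

In this assay, replacing the nitrile with acetamido recovers only part of the ground lost (a 2.1-fold lower number from compound 3 to compound 4 (0.33 log units; beyond the scatter)), and acetamido still gives a higher number than plain hydrogen on this carbon (a 4.3-fold higher number from compound 1 to compound 4 (0.63 log units; beyond the scatter)). It also falls well short of carbamoyl (a 7.1-fold higher number from compound 2 to compound 4 (0.85 log units; beyond the scatter)), so this position tells apart two amide groups, one joined through its carbonyl carbon and the other through its nitrogen, and only carbamoyl stays within the scatter of hydrogen. Nothing measured here explains why these groups differ.

The compounds shown leave open whether a free amine on this carbon would stay close to hydrogen and carbamoyl. They also leave open whether a longer acyl chain, such as propionamido, would raise the number further than acetamido does.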